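A few compounds are considered here, and "the series" means these few. Any claim that something is new, unique, unknown or untested is made for them only; others in the source may bear on it.

In a physicochemical assay for lipophilicity, measured as octanol-water partition, at pH 7.4 (a lower number here means a more polar compound, a higher number a more lipophilic compound), compound 2 `Cc1cccc(Cn2c(=O)[nH]c3c(N)nc(C(F)(F)F)cc32)n1` reads 2.3. Compound 3 `Cc1nc(Cn2c(=O)[nH]c3c(N)nc(C(F)(F)F)cc32)cs1` stands level with it at 2.3, and compound 1 `Cc1ccc(Cn2c(=O)[nH]c3c(N)nc(-c4ncco4)cc32)cn1` lies lower at 1.6. For the measured compounds named here, compound 1 differs from compound 2 in more than one place, so it offers no clean step. The unmeasured compound 4 `Cc1nc(Cn2c(=O)[nH]c3c(N)nc(C(F)(F)F)cc32)co1` carries a single change: 2-methyl-1,3-oxazol-4-yl in place of 6-methylpyridin-2-yl on a saturated chain carbon bound to an aromatic nitrogen. Going by the values given here, one measured step bears on this, 2-methyl-1,3-thiazol-4-yl in place of the same 6-methylpyridin-2-yl at the same place: no change at the digits printed from compound 2 to compound 3 (within the scatter). Among the compounds with values here, no compound with 2-methyl-1,3-oxazol-4-yl at this place has been measured, so that step is only a loose guide. A modest fall is expected, an estimated a number 0.40 log units lower from compound 2 to compound 4 (beyond the scatter). The estimate for compound 4 is 1.9, with an expected range of 1.5 to 2.3.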

Compound 4, distribution coefficient: 1.7
The estimate for compound 4 lay 0.20 log units above the measured number; low and high end bracket the measured number.
By their numbers in this assay, from the lowest: compounds 1 and 4 (each within the scatter of the next); then compounds 2 and 3 (each within the scatter of the next).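

In this assay this place proves sensitive to the ring it carries: 2-methyl-1,3-oxazol-4-yl gives a number 0.60 log units lower from compound 2 to compound 4 (beyond the scatter) and, set against 2-methyl-1,3-thiazol-4-yl, a number 0.60 log units lower from compound 3 to compound 4 (beyond the scatter) as well. Compound 2 and compound 3 alone had shown no response at this place, so ring size by itself does not settle the number here. On these data alone, whether an amine or a carboxylic acid on this ring would shift the number, and whether the step holds with another group in place of trifluoromethyl, stays open. Nothing at hand explains the fall.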